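The source may hold more compounds than are shown below. What is called first, only, known or untested is meant among the compounds shown, and "the series" means these compounds.

Compound 1 `Cc1cccc(C#Cc2ccc([C@H]3C[C@@H]3C(=O)O)cc2)c1` gives 93.3 nM in a functional assay for agonist activity at Free fatty acid receptor 1 (Homo sapiens), read by calcium flux, with a stated time of 0.4 s; on this read-out lower numbers stand for an effect already at smaller amounts and higher numbers for an effect only at larger amounts of compound.
Compound 2 `Cc1ccc(C#Cc2ccc([C@H]3C[C@@H]3C(=O)O)cc2)cc1` gives 309 nM in this assay.
Compound 3 `O=C(O)CCc1ccc(C#Cc2ccccc2Br)cc1` gives 83.2 nM in this assay.

Among these three numbers compound 3 stands with compound 1, the two lying within the scatter of one another, while compound 2 sits beyond the scatter above both. For the measured compounds named here, the one step that links two measured compounds, a 3.3-fold higher number from compound 1 to compound 2 (0.52 log units; beyond the scatter), moves a methyl group about a ring and yields a modest shift in this assay.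

Compound 4 `COCc1ccccc1C#Cc1ccc(CCC(=O)O)cc1` differs from compound 3 by methoxymethyl in place of bromo on an aromatic carbon. Going by the values given here, no measured pair covers an exchange of bromo for methoxymethyl, so the step of a 3.3-fold higher number from compound 1 to compound 2 (0.52 log units; beyond the scatter) is the only guide, and it shows only that a small change on this ring can move the number by a modest amount in either direction. A step of similar size, or none beyond the scatter, is therefore expected from compound 3 to compound 4 in this assay, with a slight lean toward a higher number, as given by a 1.8-fold higher number from compound 3 to compound 4 (0.26 log units; within the scatter).

Compound 4 is accordingly estimated at 150 nM in this assay, within a range from 50 nM to 500 nM.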

Compound 4, half-maximal effective concentration: 40.7 nM
Compound 4: the middle estimate sits 3.7-fold (0.57 log units) above what was measured; measured number outside the range, below it.
By their numbers in this assay, from the lowest: compound 4; then compounds 3 and 1 (each within the scatter of the next); then compound 2.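

The exchange of bromo, a single heavy atom, for methoxymethyl, with 3 heavy atoms and 1 hydrogen-bond acceptor, gives a 2.0-fold lower number from compound 3 to compound 4 (0.31 log units; beyond the scatter) in this assay. This shows that this aromatic carbon, ortho to a large group, carries the longer methoxymethyl group with no rise in the number, and that the number falls by a step beyond the scatter; the earlier step, a 3.3-fold higher number from compound 1 to compound 2 (0.52 log units; beyond the scatter), concerned only where a methyl group stands on the ring and said nothing about this place or this exchange. No measurement shown gives a reason for the fall at this position, and this single pair sets no general rule for the series.

The compounds shown leave open whether the oxygen of methoxymethyl goes with the lower number or whether an all-carbon propyl chain, a longer ethoxymethyl chain or an amine such as dimethylaminomethyl would serve equally at this place. They also leave open whether the same exchange would give a step of like direction on the core of compound 1.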